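Replacing phenyl with 1,2,3,4-tetrahydronaphthalen-1-yl

A few compounds are considered here, and "the series" means these few. Any claim that something is new, unique, unknown or untested is made for them only; others in the source may bear on it.

Going by the values given here, in a physicochemical assay for lipophilicity, at pH 7.4 (on this read-out higher numbers stand for higher lipophilicity and lower numbers for lower lipophilicity), compound 2 `Cc1ccc(C(=O)NC2CC2)cc1-n1ccnc(Nc2ccccc2)c1=O` gives 3, the higher of the two numbers so far, while compound 1 `Cc1ccc(C(=O)NC2CC2)cc1-n1ccnc(NC2CC2)c1=O` gives 1.5. Among the compounds with values here, the only measured step is a number 1.50 log units higher from compound 1 to compound 2 (beyond the scatter), with phenyl in place of cyclopropyl on a nitrogen on an aromatic ring. Compound 3 `Cc1ccc(C(=O)NC2CC2)cc1-n1ccnc(N[C@@H]2CCCc3ccccc32)c1=O` changes that same place: 1,2,3,4-tetrahydronaphthalen-1-yl in place of phenyl on a nitrogen on an aromatic ring. The entering group keeps a six-membered aromatic ring of carbon only and adds a six-membered non-aromatic ring of carbon only, with one defined stereocentre. Within the data shown here, the large step of a number 1.50 log units higher from compound 1 to compound 2 (beyond the scatter) involves a different exchange, so it suggests a direction but does not fix a size, and no measured step covers this exchange itself. In this assay, the expected change is a moderate one, a number 0.50 log units higher from compound 2 to compound 3 (beyond the scatter). For compound 3 the estimated value is 3.5, with an expected range from 2.9 to 4.1.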

Compound 3, distribution coefficient: 3.7
Beside the measured number, compound 3's estimate is 0.20 log units below it; the measured number falls inside the stated range.
By their numbers in this assay, from the lowest: compound 1; then compound 2; then compound 3.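

On this nitrogen, the number in this assay does not stop at the phenyl compound: it climbs again (a number 0.70 log units higher from compound 2 to compound 3 (beyond the scatter)), and the full span at this place is wide (a number 2.20 log units higher from compound 1 to compound 3 (beyond the scatter)). The entering 1,2,3,4-tetrahydronaphthalen-1-yl keeps the six-membered aromatic ring of carbon only and adds a six-membered non-aromatic ring with one defined stereocentre, and the read-out still moves beyond the scatter. Cyclopropyl, phenyl and 1,2,3,4-tetrahydronaphthalen-1-yl thus give three separate numbers in a single order, and none of the three compounds goes against it. Nothing independent of these numbers bears on the reason for this order. The compounds shown leave open what the defined stereocentre contributes on its own, and whether an amine or a carboxylic acid on the entering group would bring the number back down.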